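Triazole substituent variation on a furanone series: antiproliferative data

A few compounds are considered here, and "the series" means these few. Any claim that something is new, unique, unknown or untested is made for them only; others in the source may bear on it.

Measured compounds:
compound 1, `O=C1O[C@H]([C@@H](O)Cn2cc(CNS(=O)(=O)c3ccc(F)cc3)nn2)C(OCc2ccccc2)=C1OCc1ccccc1`, 34700 nM
compound 2, `O=C1O[C@H]([C@@H](O)Cn2cc(C3CC3)nn2)C(OCc2ccccc2)=C1OCc1ccccc1`, 47700 nM

In a functional assay on CFPAC-1 cells (Homo sapiens) for antiproliferative activity, read by MTT assay, with a stated time of 72 h (a higher number here means a weaker inhibitor, a lower number a stronger inhibitor), compound 1 gives 34700 nM. In the same assay compound 2 gives 47700 nM. Compound 2 carries the higher of the two numbers, but the step of a 1.4-fold higher number from compound 1 to compound 2 (0.14 log units; within the scatter) lies within the scatter, so the two compounds are indistinguishable on the numbers shown.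

Compound 3, `O=C1O[C@H]([C@@H](O)Cn2cc(-c3cc(F)cc(F)c3)nn2)C(OCc2ccccc2)=C1OCc1ccccc1`, has not yet been measured. It differs from compound 2 at one place: 3,5-difluorophenyl in place of cyclopropyl on an aromatic carbon.

Going by the values given here, only one measured step bears on this change, the exchange of the substituent on the same aromatic carbon, a 1.4-fold higher number from compound 1 to compound 2 (0.14 log units; within the scatter). That exchange of a large polar group for a small carbocycle moved the number by less than the scatter. The series therefore gives no sign that the group on this carbon controls the read-out, and the step to compound 3 is expected to stay within the scatter as well, a 1.4-fold lower number from compound 2 to compound 3 (0.13 log units; within the scatter), with no direction favoured.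

For compound 3 the expected value in this assay is 35000 nM, with a range from 12000 nM to 100000 nM.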

Compound 3, half-maximal inhibitory concentration: 62400 nM
Estimate against measurement, compound 3: 1.8-fold (0.25 log units) below; the range from low to high includes it.
By their numbers in this assay, from the lowest: compounds 1, 2 and 3 (each within the scatter of the next).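

In this assay, the position tolerates a change from cyclopropyl, a three-membered non-aromatic ring of 3 heavy atoms, to 3,5-difluorophenyl, a six-membered aromatic ring of 8 heavy atoms, with a 1.3-fold higher number from compound 2 to compound 3 (0.12 log units; within the scatter). Going by these compounds alone, the comparison with the sulfonamide-bearing group, (((4-fluorophenyl)sulfonyl)amino)methyl, gives a 1.8-fold higher number from compound 1 to compound 3 (0.25 log units; within the scatter), so this pair also stays within the scatter, and the three groups on this aromatic carbon now form a set that the read-out does not separate, where the earlier pair offered only two groups. No measurement is available that would account for this flat response at the position.

Going by these compounds, it remains open whether a primary amine, a carboxylic acid or a longer alkyl chain on this aromatic carbon would produce a step beyond the scatter. On these data alone, the two benzyl ethers are common to all three compounds, so the effect of replacing either one with a free hydroxyl, and whether such a change would move the number in this assay more than the exchanges at this carbon, also remains open.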